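A few compounds are considered here, and "the series" means these few. Any claim that something is new, unique, unknown or untested is made for them only; others in the source may bear on it.

Compounds measured in a physicochemical assay for solubility; on this read-out higher numbers stand for higher solubility and lower numbers for lower solubility:

Compound 1 `N#Cc1cccc(S(=O)(=O)N2CCC(NS(=O)(=O)c3cc(S(=O)(=O)c4ccccc4)ccc3C(F)(F)F)CC2)c1` gives 6300 nM.
Compound 2 `O=S(=O)(NC1CCN(S(=O)(=O)c2cccc(-c3nnn[nH]3)c2)CC1)c1cc(S(=O)(=O)c2ccccc2)ccc1C(F)(F)F` gives 100000 nM.
Compound 3 `CC(C)(C)OC(=O)N1CCC(C(=O)N2CCC(NS(=O)(=O)c3cc(S(=O)(=O)c4ccccc4)ccc3C(F)(F)F)CC2)CC1` gives 25000 nM.

Compound 1 stands lowest of the three numbers in this assay; compound 3 is the nearest, and compound 2 the furthest from it. Among the measured compounds shown here, the one step available is a 16-fold higher number from compound 1 to compound 2 (1.20 log units; beyond the scatter), a change at a different place from the one considered here.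

Compound 4 `O=C(CC1CCNCC1)N1CCC(NS(=O)(=O)c2cc(S(=O)(=O)c3ccccc3)ccc2C(F)(F)F)CC1` is not yet measured. Against compound 1 the change is ((piperidin-4-yl)methyl)carbonyl in place of (3-cyanophenyl)sulfonyl on an amine nitrogen in a ring. For the measured compounds named here, no measured step shares this change; the only bearing comes from compound 3, which carries a different group at the same ring nitrogen and gives a higher number than compound 1 in this assay, and from compound 2, whose step from compound 1 shows that a single change at the edge of the core can move the number far beyond the scatter. On that basis the number for compound 4 is expected to rise beyond the scatter, with the step from compound 1 estimated as a 9.5-fold higher number from compound 1 to compound 4 (0.98 log units; beyond the scatter). Compound 4 is therefore estimated at 60000 nM in this assay, within an expected range of 20000 nM to 200000 nM.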

Compound 4, solubility: 100000 nM
For compound 4 the middle estimate is 1.7-fold (0.22 log units) below the measured one, and the stated range covers the measured number.
By their numbers in this assay, from the lowest: compound 1; then compound 3; then compounds 2 and 4 (each within the scatter of the next).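

In this assay the step of a 16-fold higher number from compound 1 to compound 4 (1.20 log units; beyond the scatter) shows that this amine nitrogen in a ring allows exchange of the whole (3-cyanophenyl)sulfonyl, whereas the earlier step changed only the nitrile on that group. Compound 4 and compound 2 stand within the scatter of each other, although the ((piperidin-4-yl)methyl)carbonyl of compound 4 has no aromatic ring and the group at the same nitrogen in compound 2 keeps one, so an aromatic ring at this place is not required for a number of this size. No measurement on hand offers an explanation for the step.

Open, from the compounds shown here alone, is whether the ring nitrogen of the piperidin-4-yl matters: a cyclohexyl on the same methylcarbonyl link would test this. Also open, going by these compounds, is how a carboxylic acid on the phenylsulfonyl would compare with the tetrazolyl of compound 2.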